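A methoxy to hydroxy step from compound 2

This account rests on a few compounds, and the source may have more. Where it says the series, first, only, none or still open, it means among the compounds named here.

Measured in a functional assay on KB cells (Homo sapiens) for antiproliferative activity, read by sulforhodamine B assay, with a stated time of 72 h; a lower number here means a stronger inhibitor, a higher number a weaker inhibitor:
- compound 1 `CCOc1cc2occ(-c3csc4ccccc34)c(=O)c2c(OCC)c1OC`: 4200 nM
- compound 2 `COc1cc2occ(-c3csc4ccccc34)c(=O)c2c(OC)c1OC`: 820 nM

Compound 2 holds the lower of the two numbers, which makes it the stronger inhibitor of this pair, and its gap to compound 1 lies beyond the usual scatter. The next compound, compound 3 `COc1cc2occ(-c3csc4ccccc34)c(=O)c2c(OC)c1O`, departs from compound 2 in one place: hydrogen in place of methyl on an oxygen on an aromatic ring. This puts hydrogen in place of methyl on an oxygen on an aromatic ring, a change from methoxy to hydroxy. Among the compounds with values here, no measured pair shows this change alone, so the data give no direct guide. A modest weakening in this assay is expected, though a result within the scatter would be no surprise. The estimated change is a 1.8-fold higher number from compound 2 to compound 3 (0.26 log units; within the scatter). For compound 3 the expected value is 1500 nM, with an estimated range of 350 nM to 6500 nM.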

Compound 3, half-maximal inhibitory concentration: > 10000 nM
Compound 3 gave a limit, no number (the forecaster's own chance of this, stated with the estimate: 10%); middle value at least 6.6-fold (0.82 log units) from the limit.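

In this assay compound 3 gives > 10000 nM, which is a limit of the assay and not a number. Hydrogen in place of methyl on this oxygen on an aromatic ring therefore gives an at least 12-fold higher number from compound 2 to compound 3 (1.08 log units; beyond the scatter), the first direct reading of the change from methoxy to hydroxy, and it shows that this one methyl cannot be lost here without a large step toward weaker inhibition. This reading rests on one pair and on a limit rather than a measured value: the limit of > 10000 nM in this assay, at which 1 of the 3 values shown sits.

Going by these compounds, how far compound 3 lies past its limit remains open. So does whether an amine, a fluorine atom or a longer chain on the ether oxygen at this same place would keep the activity of compound 2 in this assay.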